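A few compounds are considered here, and "the series" means these few. Any claim that something is new, unique, unknown or untested is made for them only; others in the source may bear on it.

Values in a functional assay on COLO 205 cells (Homo sapiens) for inhibition, read by sulforhodamine B assay, with a stated time of 48 h, tested at 50 uM (a lower number here means less inhibition of growth, a higher number more inhibition of growth at the concentration tested), so far
compound 1 `COc1ccc(/C=C/C(=O)/C=C/c2ccc(OCc3cn(CCCCCOc4cc(=O)oc5ccccc45)nn3)c(OC)c2)cc1OC` gives 43%
compound 2 `COc1ccc(/C=C/C(=O)/C=C/c2ccc(OCc3cn(CCCCCOc4cc(=O)oc5ccccc45)nn3)c(OC)c2)cc1` gives 30%
compound 3 `COc1cc(/C=C/C(=O)/C=C/c2ccccc2)ccc1OCc1cn(CCCCCOc2cc(=O)oc3ccccc23)nn1` gives 22%

Among the measured compounds shown here, the number for compound 3 is clearly separated from only one neighbour: the measurements show a number 21 percentage points lower from compound 1 to compound 3 (beyond the scatter) but also a number 8 percentage points lower from compound 2 to compound 3 (within the scatter) in this series. Compound 4 `COc1cc(/C=C/C(=O)/C=C/c2ccco2)ccc1OCc1cn(CCCCCOc2cc(=O)oc3ccccc23)nn1` carries furan-2-yl in place of phenyl on a double-bonded chain carbon bound to a double-bonded chain carbon. The steps bearing on this, together with a number 13 percentage points lower from compound 1 to compound 2 (beyond the scatter) as well, all remove methoxy groups from the group at that place. For the measured compounds named here, no measured step exchanges the ring itself, so they are only a loose guide. The expected result is a number 3 percentage points higher from compound 3 to compound 4 (within the scatter) and no shift beyond the scatter. The estimated value for compound 4 is 25% (expected range 13% to 37%).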

Compound 4, percent growth inhibition at one concentration: 33%
For compound 4 the middle estimate is 8 percentage points below the measured one; measured number inside the range.
By their numbers in this assay, from the lowest: compounds 3, 2, 4 and 1 (each within the scatter of the next, the first and the last beyond it).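

Furan-2-yl in place of phenyl on a double-bonded chain carbon bound to a double-bonded chain carbon gives a clear shift in this assay (a number 11 percentage points higher from compound 3 to compound 4 (beyond the scatter)), so exchanging the ring itself, and not only removing methoxy groups, moves the number at this place. The same ring stands within the scatter of both methoxy-bearing groups (a number 3 percentage points higher from compound 2 to compound 4 (within the scatter); a number 10 percentage points lower from compound 1 to compound 4 (within the scatter)). Nothing measured here gives a reason for the shift. From the compounds shown here alone, whether thiophen-2-yl or 4-(dimethylamino)phenyl at this place would score like furan-2-yl remains open.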